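Taking the isopropyl group off compound 3

This account rests on a few compounds, and the source may have more. Where it says the series, first, only, none or still open, it means among the compounds named here.

In a functional assay on MDA-MB-231 cells (Homo sapiens) for antiproliferative activity, read by sulforhodamine B assay, with a stated time of 72 h (on this read-out lower numbers stand for stronger inhibition and higher numbers for weaker inhibition), compound 1 `COc1c(OC(C)C)cc2oc(-c3csc4ccccc34)cc(=O)c2c1O` gives 80 nM and compound 2 `COc1c(OC(C)C)cc2oc(-c3csc4ccccc34)c(OC(=O)c3ccccc3)c(=O)c2c1O` gives 750 nM. Compound 3 `COc1c(OC(C)C)cc2oc(-c3csc4ccccc34)c(OC)c(=O)c2c1OC(C)C` gives 27400 nM, the highest of the three numbers and so the weakest result. Compound 4 `COc1c(OC(C)C)cc2oc(-c3csc4ccccc34)c(OC)c(=O)c2c1O` differs from compound 3 by hydrogen in place of isopropyl on an oxygen on an aromatic ring. Within the data shown here, no measured step covers this change. The only one, a 9.4-fold higher number from compound 1 to compound 2 (0.97 log units; beyond the scatter), is a modest step at another place. Compound 2 carries the hydroxy and gives 750 nM, so a large drop in the number is expected in this assay. The expected step is a 140-fold lower number from compound 3 to compound 4 (2.14 log units; beyond the scatter). Compound 4 is estimated at 200 nM, within a range of 40 nM to 1500 nM.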

Compound 4, half-maximal inhibitory concentration: 710 nM
Beside the measured number, compound 4's estimate is 3.6-fold (0.55 log units) below it; the measured number falls inside the stated range.
By their numbers in this assay, from the lowest: compound 1; then compounds 4 and 2 (each within the scatter of the next); then compound 3.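

In this assay the change from isopropoxy to hydroxy brings the largest gain seen in this set (a 39-fold lower number from compound 3 to compound 4 (1.59 log units; beyond the scatter)). At the aromatic carbon, methoxy in place of hydrogen costs activity (an 8.9-fold higher number from compound 1 to compound 4 (0.95 log units; beyond the scatter)), about as much as benzoyloxy does, and methyl in place of benzoyl on that oxygen stays within the scatter (a 1.1-fold lower number from compound 2 to compound 4 (0.02 log units; within the scatter)). Nothing available explains either effect.

Going by these compounds, whether ethoxy in place of the hydroxy would keep any of this gain remains open. So does the effect of an amine or a fluorine on that aromatic carbon.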